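The source may report more compounds than this note shows. Statements on the series, on what has been measured and on what is new or still open speak of the compounds shown alone.

Measured compounds in a functional assay on LoVo cells (Homo sapiens) for inhibition, read by MTT assay, with a stated time of 24 h; on this read-out higher numbers stand for weaker inhibition and lower numbers for stronger inhibition:
- compound 1 `CC1(C)[C@H]2CC[C@]1(C)N(Cc1cn(-c3cccc(C#N)c3)nn1)C(=O)C2`: 320 nM
- compound 2 `CC1(C)[C@H]2CC[C@]1(C)N(Cc1cn(-c3ccc(Br)cc3)nn1)C(=O)C2`: 60 nM
- compound 3 `CC1(C)[C@H]2CC[C@]1(C)N(Cc1cn(-c3ccccc3O)nn1)C(=O)C2`: 540 nM

Compound 1 stands second highest of the three numbers in this assay; compound 3 differs from it only by a 1.7-fold higher number from compound 1 to compound 3 (0.23 log units; within the scatter), while compound 2 sits clearly lower, by a 5.3-fold lower number from compound 1 to compound 2 (0.73 log units; beyond the scatter). Compound 4 `COc1cccc(-n2cc(CN3C(=O)C[C@@H]4CC[C@@]3(C)C4(C)C)nn2)c1` differs from compound 1 by methoxy in place of cyano on an aromatic carbon. For the measured compounds named here, no measured step changes a group at this same position: a 5.3-fold lower number from compound 1 to compound 2 (0.73 log units; beyond the scatter) and a 9.0-fold higher number from compound 2 to compound 3 (0.95 log units; beyond the scatter) each replace the whole aryl group and its substitution pattern, and a 1.7-fold higher number from compound 1 to compound 3 (0.23 log units; within the scatter) stays within scatter. Going by the values given here, no measured step therefore bears directly on this change, and no step beyond the scatter is expected, in either direction. Compound 4 is estimated at 320 nM, within 100 nM to 1000 nM, a step of no change at the digits printed from compound 1 to compound 4 (within the scatter) expected from compound 1.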

Compound 4, half-maximal inhibitory concentration: 80 nM
Compound 4: the middle estimate sits 4.0-fold (0.60 log units) above what was measured; the measured number lies below the stated range.
By their numbers in this assay, from the lowest: compounds 2 and 4 (each within the scatter of the next); then compounds 1 and 3 (each within the scatter of the next).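

In this assay, for the compounds shown here, the swap of cyano for methoxy on this aromatic carbon, meta to a large group, is the first change confined to one substituent, and it gives a 4.0-fold lower number from compound 1 to compound 4 (0.60 log units; beyond the scatter) without altering the substitution pattern. The 3-methoxyphenyl group also gives a 1.3-fold higher number from compound 2 to compound 4 (0.12 log units; within the scatter) while remaining apart from the 2-hydroxyphenyl group, with a 6.8-fold lower number from compound 3 to compound 4 (0.83 log units; beyond the scatter) as the step. No measurement in hand explains the methoxy result.

Going by these compounds, how an amine, a carboxylic acid or a longer ether chain would read at this same place remains open. Also open, on these data alone, is whether the methoxy result holds on other aryl substitution patterns.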